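Swapping methyl for pyridin-3-yl: what to expect for compound 4

The source may report more compounds than this note shows. Statements on the series, on what has been measured and on what is new or still open speak of the compounds shown alone.

Measured in an ADME assay for pharmacokinetics; on this read-out lower numbers stand for a shorter-lived compound and higher numbers for a longer-lived compound:
compound 1, `CC(=O)NCC(/C=C1\CCCCC1[N+](=O)[O-])=N\O`, gives 1.45 h
compound 2, `CC/C(=C\C(CNC(C)=O)=N\O)C(C)[N+](=O)[O-]`, gives 1.43 h
compound 3, `O=C(NCC(/C=C1\CCCCC1[N+](=O)[O-])=N\O)c1cccnc1`, gives 1.4 h

Compound 3 differs from compound 1 by one change, (pyridin-3-yl in place of methyl on a carbonyl carbon). That change gave a 1.0-fold lower number from compound 1 to compound 3 (0.02 log units; within the scatter). Compound 4, `CC/C(=C\C(CNC(=O)c1cccnc1)=N\O)C(C)[N+](=O)[O-]`, has not yet been measured; it stands to compound 2 as compound 3 stands to compound 1, through (pyridin-3-yl in place of methyl on a carbonyl carbon). The place is described in the same words for both pairs, so this is the same change made on a second core. How the core of compound 2 differs from that of compound 1 is not broken down here; their two values lie within the scatter of each other. The expected step is a 1.0-fold lower number from compound 2 to compound 4 (0.01 log units; within the scatter), about the size of the earlier one, because a 1.0-fold lower number from compound 1 to compound 3 (0.02 log units; within the scatter) stayed within the scatter. Compound 4 is therefore expected to give 1.4 h, most likely between 0.9 h and 2.2 h.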

Compound 4, half-life: 1.78 h
Compound 4: middle estimate off by 1.3-fold (0.10 log units), on the low side; the measured number falls inside the stated range.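

In this assay the swap of methyl for pyridin-3-yl on a carbonyl carbon gave a 1.2-fold higher number from compound 2 to compound 4 (0.10 log units; within the scatter). Set beside the earlier step, the change looks the same on both cores: the same change on two cores in this assay, a 1.0-fold lower number (0.02 log units; within the scatter) from compound 1 to compound 3 and a 1.2-fold higher number (0.10 log units; within the scatter) from compound 2 to compound 4, 1.3-fold (0.11 log units) apart, within the scatter of two such steps. This shows that, on these two cores, the swap left the half-life within the usual scatter, but two pairs cannot show that this holds on other cores, or that a step large enough to read would carry over.

The compounds shown leave open what other groups on that carbonyl carbon would do, such as a phenyl ring, an amine or a longer chain.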